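A few compounds are considered here, and "the series" means these few. Any claim that something is new, unique, unknown or untested is made for them only; others in the source may bear on it.

Compound 1 `Cc1cc(COc2ccccc2Cl)nc(-c2ccccn2)n1` gives 316 nM.
Compound 2 `Cc1cc(COc2cccc(F)c2F)nc(-c2ccccn2)n1` gives 398 nM.
Compound 3 `COc1cc(COc2cccc(F)c2)nc(-c2ccccn2)n1` gives 1260 nM.

These numbers come from a functional assay on cells for antagonist activity at Free fatty acid receptor 1 (Homo sapiens), read by TR-FRET and inositol phosphate accumulation, with a stated time of 2 h; on this read-out lower numbers stand for stronger inhibition and higher numbers for weaker inhibition. Among the three, compound 3 has the highest number and is therefore the weakest inhibitor of the set; compound 2 and compound 1 both stand beyond the usual scatter from it. Compound 4 `CCNc1cc(COc2cccc(F)c2)nc(-c2ccccn2)n1` differs from compound 3 in a single place: ethylamino in place of methoxy on an aromatic carbon. For the measured compounds named here, no pair of measured compounds shows this exact change, so there is nothing to carry over directly. With only that to go on, the expected step from compound 3 to compound 4 in this assay is small and may not reach beyond the scatter: a 1.3-fold lower number from compound 3 to compound 4 (0.10 log units; within the scatter). Compound 4 is estimated at 1000 nM, with a range from 300 nM to 3200 nM.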

Compound 4, half-maximal inhibitory concentration: 631 nM
Compound 4: middle estimate off by 1.6-fold (0.20 log units), on the high side; the range from low to high includes it.
By their numbers in this assay, from the lowest: compounds 1, 2, 4 and 3 (each within the scatter of the next, the first and the last beyond it).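

In this assay, putting ethylamino in place of methoxy on the aromatic carbon next to the ring nitrogen gives a 2.0-fold lower number from compound 3 to compound 4 (0.30 log units; within the scatter) and so no clear change. This position therefore accepts a group with one more heavy atom and a hydrogen-bond donor while the number stays within the usual scatter. No measurement shown here explains this result.
The compounds shown leave open how much the chain and the nitrogen each contribute. Ethoxy or methylamino at this position would help separate the two.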